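This account rests on a few compounds, and the source may have more. Where it says the series, first, only, none or still open, it means among the compounds named here.

Measured compounds:
Compound 1, `C=C(C)C(=O)c1ccc(OCc2nc(-c3ccc(F)cc3)no2)cc1C`, in an assay on HL-60 cells for inhibition of glutathione S-transferase P (Homo sapiens); a lower number here means a stronger inhibitor, a higher number a weaker inhibitor: 3500 nM
Compound 2, `C=C(C)C(=O)c1ccc(OCc2nc(-c3ccccc3)no2)c(C)c1C`, in this assay: 1800 nM
Compound 3, `C=C(C)C(=O)c1ccc(OCc2nc(-c3ccc(O)cc3)no2)c(C)c1C`, in this assay: 3400 nM

Compound 3 lies within the scatter of both other measured compounds: its nearest is compound 1, and the step from compound 2 to compound 3 (a 1.9-fold higher number from compound 2 to compound 3 (0.28 log units; within the scatter)) is also within the scatter. Among the compounds with values here, on these three numbers no one compound is separated from the others.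

Compound 4, `C=C(C)C(=O)c1ccc(OCc2nc(-c3ccc([N+](=O)[O-])cc3)no2)c(C)c1C`, is not yet measured. It differs from compound 3 by nitro in place of hydroxy on an aromatic carbon. Within the data shown here, the only measured step at this aromatic carbon is a 1.9-fold higher number from compound 2 to compound 3 (0.28 log units; within the scatter), where hydroxy replaced hydrogen; that step stayed within the scatter. Among the measured compounds shown here, no measured compound in this set carries a nitro group, so the change from hydroxy to nitro has no direct precedent here. Taken together, the available steps give no basis for expecting a move in this assay beyond the scatter in either direction, and the expected step from compound 3 to compound 4 is a 1.1-fold lower number from compound 3 to compound 4 (0.03 log units; within the scatter), i.e. none of consequence.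

For compound 4 the expected value in this assay is therefore 3200 nM, with a range from 1100 nM to 9500 nM, the width reflecting the absence of any measured nitro analogue.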

Compound 4, half-maximal inhibitory concentration: 2300 nM
For compound 4 the middle estimate is 1.4-fold (0.14 log units) above the measured one, within the range that was stated.
By their numbers in this assay, from the lowest: compounds 2, 4, 3 and 1 (each within the scatter of the next).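

In this assay, the change from 4-hydroxyphenyl to 4-nitrophenyl gives a 1.5-fold lower number from compound 3 to compound 4 (0.17 log units; within the scatter), and nitro in place of hydrogen on the same aromatic carbon gives a 1.3-fold higher number from compound 2 to compound 4 (0.11 log units; within the scatter). The aromatic carbon para to a large group has now been read with hydrogen, hydroxy and nitro on an otherwise unchanged core, and the three compounds are not separated, so neither removing the hydrogen-bond donor of hydroxy nor placing the larger nitro group there moves the number beyond the scatter. No data at hand bear on why the number stays within the scatter at this position.

Still open, going by these compounds, is whether this flat reading holds beyond these groups, since an amine, a carboxylic acid or a longer chain such as butoxy on the same carbon could yet move the number beyond the scatter in this assay. Compound 1 carries fluoro at this carbon but also differs from the others elsewhere on the core, so its fluoro group cannot be set directly against hydrogen, hydroxy or nitro.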